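From methoxy to trifluoromethyl on a shared core

A few compounds are considered here, and "the series" means these few. Any claim that something is new, unique, unknown or untested is made for them only; others in the source may bear on it.

Compound 1 `COc1ccc(/C=C2\CN(C)C/C(=C\c3ccccc3F)C2=O)cc1` gives 12300 nM
Compound 2 `COc1ccc(/C=C2\CN(C)C/C(=C\c3ccccc3F)C2=O)cc1OC` gives 8760 nM

In a functional assay on HepG2 cells (Homo sapiens) for cytotoxicity, read by MTT assay, with a stated time of 24 h (a lower number here means a stronger inhibitor, a higher number a weaker inhibitor), compound 1 gives 12300 nM and stands level with compound 2 at 8760 nM in this pair of measured compounds, the two values lying within the scatter of each other.

Compound 3 `CN1C/C(=C\c2ccc(C(F)(F)F)cc2)C(=O)/C(=C/c2ccccc2F)C1` has not yet been measured. It differs from compound 1 by trifluoromethyl in place of methoxy on an aromatic carbon and keeps the rest of the core. Among the compounds with values here, no measured compound carries trifluoromethyl. Within the data shown here, the only measured step that bears on this change is a 1.4-fold lower number from compound 1 to compound 2 (0.15 log units; within the scatter) for methoxy in place of hydrogen on an aromatic carbon. That step, to compound 2, adds a methoxy without removing one, so it offers indirect guidance only. On this evidence no shift beyond the scatter is expected in this assay in either direction. The expected change is a 1.2-fold lower number from compound 1 to compound 3 (0.09 log units; within the scatter) and would stay within the scatter. Compound 3 is estimated at 10000 nM with an expected range of 4000 nM to 25000 nM for the measurement still to come.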

Compound 3, half-maximal inhibitory concentration: 4140 nM
Compound 3: the middle estimate sits 2.4-fold (0.38 log units) above what was measured; low and high end bracket the measured number.
By their numbers in this assay, from the lowest: compound 3; then compounds 2 and 1 (each within the scatter of the next).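

In this assay, trifluoromethyl in place of methoxy on an aromatic carbon, para to a large group, gives a 3.0-fold lower number from compound 1 to compound 3 (0.47 log units; beyond the scatter), a modest step but the only one shown that lies beyond the scatter. The earlier step, a 1.4-fold lower number from compound 1 to compound 2 (0.15 log units; within the scatter), showed only that a second methoxy on that ring left the number within the scatter, whereas this result shows that the number does respond to a change of the group at this position. Nothing available on the properties of these groups or on how the compounds act accounts for the step.

With one replacement of methoxy at this position, the compounds shown leave open whether the lower number is particular to trifluoromethyl or would also come with a nitrile, a chlorine, an amine or a carboxylic acid there. They also leave open whether the same exchange would give a step of similar size if the fluorine on the shared core were replaced by hydrogen.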